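Swapping benzyl for 4-chlorophenyl in compound 3

The source may report more compounds than this note shows. Statements on the series, on what has been measured and on what is new or still open speak of the compounds shown alone.

Compound 1 `O=[N+]([O-])c1ccc(NC(=S)NCc2cccc(Cl)c2)cc1`: 20000 nM
Compound 2 `CC1(C)CC(NC(=O)NCc2ccccc2)c2cc(Br)ccc2O1`: 38000 nM
Compound 3 `CC1(C)CC(NC(=O)NCc2ccccc2)c2cc(Cl)ccc2O1`: 15000 nM
Compound 4 `CC1(C)CC(NC(=O)Nc2ccc(Cl)cc2)c2cc(Cl)ccc2O1`: not yet measured

All these values come from a functional assay on T98G cells (Homo sapiens) for inhibition, read by MTT assay, with a stated time of 72 h; on this read-out lower numbers stand for stronger inhibition and higher numbers for weaker inhibition. Compound 3 gives 15000 nM, which lies within the scatter of compound 1 and clearly under compound 2. Compound 4 carries 4-chlorophenyl in place of benzyl on an amide-type nitrogen. Going by the values given here, no measured step changes this group. Among the compounds with values here, the only step available is a 2.5-fold lower number from compound 2 to compound 3 (0.40 log units; beyond the scatter), chloro in place of bromo on an aromatic carbon, so it offers a rough sense of scale and no guide to direction. A modest change is therefore expected, and it could fall either way, with a slight lean towards a lower number. The expected step is a 1.5-fold lower number from compound 3 to compound 4 (0.18 log units; within the scatter). The estimate for compound 4 is 10000 nM, with an expected range of 3500 nM to 28000 nM.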

Compound 4, half-maximal inhibitory concentration: 33000 nM
Compound 4: the middle estimate sits 3.3-fold (0.52 log units) below what was measured, and the stated range ends below it.
By their numbers in this assay, from the lowest: compounds 3, 1, 4 and 2 (each within the scatter of the next, the first and the last beyond it).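

In this assay, putting 4-chlorophenyl in place of benzyl on the amide-type nitrogen gives a 2.2-fold higher number from compound 3 to compound 4 (0.34 log units; beyond the scatter) and so points towards weaker inhibition. Going by these compounds alone, the only earlier step changed a halogen on an aromatic carbon, so this is the first sign that the group on this nitrogen also affects the read-out. No measurement shown here explains the shift.

From the compounds shown here alone, the change removes benzyl and brings in a chlorine together, so their separate contributions remain open. Phenyl or 4-chlorobenzyl on this nitrogen would help to tell them apart.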